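The source may hold more compounds than are shown below. What is called first, only, known or untested is meant among the compounds shown, and "the series" means these compounds.

Compound 1 `CCCCCNc1cnc(C(=O)NCc2ccccc2)cn1`: > 100000 nM
Compound 2 `CCCCNc1cncc(C(=O)NCc2ccccc2)n1`: > 100000 nM

Both measurements come from an ADME assay on HeLa cells (Homo sapiens) for cytotoxicity, read by microscopy, with a stated time of 6 days; a higher number here means that more compound is tolerated, a lower number that less compound is tolerated. For compound 1 the value > 100000 nM is a limit of the assay rather than a number. For compound 2 the value > 100000 nM is likewise a limit. Compound 2 therefore stands at the limit of > 100000 nM in this assay, at which 2 of the 2 values shown sit, so no ranking between the two can be drawn from these readings.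

Compound 3 `CCCCCNc1cncc(C(=O)NCc2ccccc2)n1` has not yet been measured. It differs from compound 2 by methyl in place of hydrogen on a saturated chain carbon, four bonds along the chain from a nitrogen on an aromatic ring.

For the measured compounds named here, no step between measured compounds is available, so nothing here shows how such a change shifts the result in this assay. Given that compound 2 sits at the limit of > 100000 nM in this assay, at which 2 of the 2 values shown sit, the step is expected to be none beyond the scatter, estimated as a number no higher from compound 2 to compound 3 (the limit leaves the size open). Compound 3 is therefore estimated at 100000 nM, with a range from 50000 nM to 200000 nM, most likely again reported as a limit.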

Compound 3, minimum cytotoxic concentration: > 100000 nM
Compound 3: no number, only a limit; the forecaster's own chance of this, stated with the estimate: 80%; the middle value sits exactly at the limit.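

Compound 2 and compound 3 both end at a limit rather than a number, so no step can be read between them: the limit of > 100000 nM in this assay, at which 3 of the 3 values shown sit. The compounds shown leave open at what concentration, if any, each would harm these cells, and whether the added methyl changes that.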